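Hydroxyacyl amide variation on the macrocyclic carboxamide series

The source may report more compounds than this note shows. Statements on the series, on what has been measured and on what is new or still open speak of the compounds shown alone.

Three macrocycles carrying the same core have been run in a functional assay on HCT-116 cells (Homo sapiens) for antiproliferative activity; on this read-out lower numbers stand for stronger inhibition and higher numbers for weaker inhibition. Compound 1 `Cc1c2c(n3c1CCCNC[C@H](C)Nc1cc-3ccc1C(N)=O)CC(C)(C)CC2=O`, with a free ring amine, gives 93 nM. Compound 2 `CC(=O)N1CCc2c(C)c3c(n2-c2ccc(C(N)=O)c(c2)N[C@@H](C)[C@H](C)C1)CC(C)(C)CC3=O`, the acetyl amide, gives 24 nM, the lowest number of the three; compound 3 `Cc1c2c(n3c1CCCN(C(=O)CO)[C@@H](C)[C@H](C)Nc1cc-3ccc1C(N)=O)CC(C)(C)CC2=O`, the hydroxyacetyl amide, gives 51 nM. The gap from compound 2 to compound 3 and the larger gap from compound 2 to compound 1 both lie beyond the usual scatter, so compound 2 stands clearly at the potent end of what has been measured.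

Compound 4 `Cc1c2c(n3c1CCN(C(=O)[C@@H](O)C(C)C)C[C@@H](C)[C@H](C)Nc1cc-3ccc1C(N)=O)CC(C)(C)CC2=O` has not yet been measured in this assay. Relative to compound 2 the change is 1-hydroxy-2-methylpropyl in place of methyl on a carbonyl carbon. Going by the values given here, no pair of measured compounds differs in this place alone, so the size of the step is open. The values of compound 2 and compound 3 show that adding a hydroxyl to the acyl group went together with a higher number; compound 4 carries that hydroxyl plus a branched chain, and the ring sizes differ as well, so only a rough expectation is possible.

For compound 4 the expected result is 45 nM, within 18 nM to 120 nM. The step of a 1.9-fold higher number from compound 2 to compound 4 (0.27 log units; within the scatter) is thus estimated as a modest loss, close to the scatter.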

Compound 4, half-maximal inhibitory concentration in the HCT-116 assay: 45 nM
For compound 4 middle estimate and measured number coincide at the digits printed; the range from low to high includes it.
By their numbers in the HCT-116 assay, from the lowest: compounds 2, 4, 3 and 1 (each within the scatter of the next, the first and the last beyond it).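

On a carbonyl carbon whose other neighbours are an amide-type nitrogen in a ring, the replacement of methyl by 1-hydroxy-2-methylpropyl, a much larger group with a hydrogen-bond donor and a defined stereocentre, leaves the HCT-116 assay without a clear shift: compound 2 gives 24 nM and compound 4 gives 45 nM with a 1.9-fold higher number from compound 2 to compound 4 (0.27 log units; within the scatter) as the step, which gives no sign that this position is restricted to a small acyl group. The same change also leaves a physicochemical assay for solubility, at pH 7.4 (a lower number here means a less soluble compound, a higher number a more soluble compound), without a clear shift: compound 2 gives 38 ug/mL and compound 4 gives 30 ug/mL with a 1.3-fold lower number from compound 2 to compound 4 (0.10 log units; within the scatter) as the step, so the larger group comes with no measurable cost on either read-out. No measurement at hand bears on the reason for either result.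

The hydroxyl, the branched chain and the stereocentre enter together in compound 4, so their separate contributions remain unresolved, and an isobutyryl amide, which has the branch without the hydroxyl, or the opposite configuration at the hydroxyl-bearing carbon would be needed to pull them apart. On these data alone, how far the position extends is also open, as an acyl group ending in an amine or a carboxylic acid, or one with a longer chain, would test a different kind of substituent at the same carbonyl carbon.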